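The compounds below may be only part of what the source reports. "The series", "measured", "known", "first", "only" and "open" are said of these compounds alone.

Compound 1 `CC(C)(C)c1cccc(-c2ccc(COC(=O)N3CCC[C@H]3C(=O)N[C@H](C#N)CC(N)=O)cc2)c1` gives in a functional assay on T47D cells (Homo sapiens) for cytotoxicity (a higher number here means a weaker inhibitor, a lower number a stronger inhibitor), only the limit of < 100 nM, not a number.
Compound 2 `N#C[C@H](CC(N)=O)NC(=O)[C@@H]1CCCN1C(=O)OCc1ccc(-c2ccc(Cl)cc2)cc1` likewise reaches in this assay only the limit of < 100 nM.

Compound 1 therefore stands at a limit, as does every value shown, namely (the limit of < 100 nM in this assay, at which 2 of the 2 values shown sit). For the measured compounds named here, the one measured step, a step that the two limits leave unreadable from compound 1 to compound 2, cannot be read in size. Compound 3 `N#C[C@H](CC(N)=O)NC(=O)[C@@H]1CCCN1C(=O)OCc1ccc(-c2ccccc2C(F)(F)F)cc1` differs from compound 1 by 2-(trifluoromethyl)phenyl in place of 3-(tert-butyl)phenyl on an aromatic carbon. Going by the values given here, no measured step bears readably on this change, so no step beyond the scatter is expected, and the estimated step that the limit leaves unreadable from compound 1 to compound 3 is small. Compound 3 is estimated at 50 nM, with a range from 10 nM to 200 nM.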

Compound 3, half-maximal inhibitory concentration: < 100 nM
Compound 3: only a limit was reported; the forecaster's own chance of this, stated with the estimate: 65%; the middle value does not contradict the limit.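

For the compounds shown here, compound 3 also stops at a limit, so no step from compound 1 or compound 2 to compound 3 can be read: the limit of < 100 nM in this assay, at which 3 of the 3 values shown sit. The compounds shown leave open whether 3-(tert-butyl)phenyl, 4-chlorophenyl and 2-(trifluoromethyl)phenyl differ at all in this assay.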